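The source may hold more compounds than are shown below. What is called first, only, known or untested is meant among the compounds shown, and "the series" means these compounds.

Compound 1 `COc1cc(-c2cc(-c3cc(C(C)C)c(O)cc3C)[nH]c(=O)c2C#N)cc(OC)c1OC`: 55%
Compound 2 `COc1ccc(-c2cc(-c3cc(C(C)C)c(O)cc3C)[nH]c(=O)c2C#N)c(OC)c1`: 37.5%
Compound 3 `COc1cc(OC)c(-c2cc(-c3cc(C(C)C)c(O)cc3C)[nH]c(=O)c2C#N)c(OC)c1`: 52.6%

In a functional assay for inhibition, tested at 40 ug/mL (on this read-out higher numbers stand for a stronger effect at the one concentration tested and lower numbers for a weaker effect), compound 2 stands lowest of the three: compound 3 lies a number 15.1 percentage points higher from compound 2 to compound 3 (beyond the scatter), and compound 1, at 55%, lies further off still, both beyond the scatter. Compound 4 `Cc1cc(O)c(C(C)C)cc1-c1cc(-c2ccco2)c(C#N)c(=O)[nH]1` differs from compound 2 by furan-2-yl in place of 2,4-dimethoxyphenyl on an aromatic carbon. For the measured compounds named here, no measured step swaps the whole aryl group at this place; the only step available, a number 15.1 percentage points higher from compound 2 to compound 3 (beyond the scatter), merely adds a methoxy to the same ring and says little about a furan-2-yl. The step to compound 4 is therefore expected to be small, a number 2.5 percentage points lower from compound 2 to compound 4 (within the scatter), possibly within the scatter. In this assay compound 4 is estimated at 35%, between 15% and 55%.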

Compound 4, a percentage reported as inhibition, at one concentration (the size of the read-out at that concentration, not a potency): 42.5%
Estimate against measurement, compound 4: 7.5 percentage points below; low and high end bracket the measured number.
By their numbers in this assay, from the lowest: compounds 2 and 4 (each within the scatter of the next); then compounds 3 and 1 (each within the scatter of the next).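

In this assay, replacing the whole aryl group gives a number 5 percentage points higher from compound 2 to compound 4 (within the scatter), so this place on the shared core accepts a furan-2-yl, with 5 heavy atoms and a single ring oxygen, in place of the 2,4-dimethoxyphenyl without a change beyond the scatter. The earlier compounds shown here varied only the methoxy groups on a phenyl ring, and this result shows that such a ring is not required to hold the number of compound 2. No measurement at hand explains this tolerance. As far as these compounds go, it remains open how a thiophene, a pyridine or a simple unsubstituted phenyl would read at this place. From the compounds shown here alone, whether an amine or a carboxylic acid on the ring would be accepted also remains open.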